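Shifting the amide chain and side chain of compound 3

The source may hold more compounds than are shown below. What is called first, only, known or untested is meant among the compounds shown, and "the series" means these compounds.

Three compounds share one core and differ only in the group on the amine. Compound 1 `CCN[C@H](c1cc(C(F)(F)F)ccc1N1CCN(C(=O)CCc2ccc(Cl)cc2Cl)CC1)C(C)CC` gives 92 nM in an assay on HEK293 cells for displacement of a labelled ligand from Melanocortin receptor 4 (Homo sapiens); on this read-out higher numbers stand for weaker inhibition and lower numbers for stronger inhibition. Compound 2 `CCC(C)CN[C@H](c1cc(C(F)(F)F)ccc1N1CCN(C(=O)CCc2ccc(Cl)cc2Cl)CC1)C(C)CC` gives 2800 nM, and compound 3 `CCC(C)[C@H](NC(=O)CN)c1cc(C(F)(F)F)ccc1N1CCN(C(=O)CCc2ccc(Cl)cc2Cl)CC1` gives 18 nM, the lowest number of the three. The step of a 30-fold higher number from compound 1 to compound 2 (1.48 log units; beyond the scatter) was large, whereas a 5.1-fold lower number from compound 1 to compound 3 (0.71 log units; beyond the scatter) and a 160-fold lower number from compound 2 to compound 3 (2.19 log units; beyond the scatter) both lowered the number. Compound 4 `CC(C)C[C@H](NC(=O)CCN)c1cc(C(F)(F)F)ccc1N1CCN(C(=O)CCc2ccc(Cl)cc2Cl)CC1` introduces (1-(((2-aminoethyl)carbonyl)amino)-3-methylbutyl in place of 1-(((aminomethyl)carbonyl)amino)-2-methylbutyl on an aromatic carbon). Within the data shown here, no measured step matches this change directly; the steps only show that changes around the amine can move the number far either way. A modest rise is therefore expected, a 2.2-fold higher number from compound 3 to compound 4 (0.35 log units; beyond the scatter), giving compound 4 an estimated 40 nM in this assay, with a range from 8 nM to 200 nM.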

Compound 4, inhibition constant: 25 nM
The estimate for compound 4 lay 1.6-fold (0.20 log units) above the measured number; the measured number falls inside the stated range.
By their numbers in this assay, from the lowest: compounds 3 and 4 (each within the scatter of the next); then compound 1; then compound 2.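

In this assay the amide chain and the side chain shift together with no change beyond the scatter, as shown by a 1.4-fold higher number from compound 3 to compound 4 (0.14 log units; within the scatter). A second compound with a carbonyl on the amine nitrogen also keeps its distance from the two alkyl amines, with a 3.7-fold lower number from compound 1 to compound 4 (0.57 log units; beyond the scatter) and a 110-fold lower number from compound 2 to compound 4 (2.05 log units; beyond the scatter). No evidence on hand accounts for these results.

Compound 4 changes both the amide chain and the side chain, so the part played by each remains unseparated. As far as these compounds go, it also remains open whether the end amine of the amide chain could give way to a carboxylic acid, or the chain could be longer still.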